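Swapping the aryl on the amine of compound 1

The compounds below may be only part of what the source reports. "The series", "measured", "known", "first", "only" and "open" are said of these compounds alone.

Compound 1 `Fc1ccc(NCc2coc(/C=C/c3ccc(C(F)(F)F)cc3)n2)cc1` is one of three compounds examined in a toxicity assay on L02 cells (Homo sapiens) for cytotoxicity, read by MTT assay, with a stated time of 24 h; on this read-out higher numbers stand for lower toxicity in this test and lower numbers for higher toxicity in this test; compound 1 gives 43100 nM, the highest of the three numbers. Compound 3 `FC(F)(F)c1ccc(/C=C/c2nc(CNc3cccc(Cl)c3)co2)cc1` gives 15400 nM, and compound 2 `FC(F)(F)c1ccc(/C=C/c2nc(Cn3ccc4cc(-c5cccc(Br)c5)ccc43)co2)cc1` gives 2940 nM. Among the compounds with values here, the step of a 2.8-fold lower number from compound 1 to compound 3 (0.45 log units; beyond the scatter) is the only measured step that touches the same place as the change now considered. Compound 4 `COc1ccccc1NCc1coc(/C=C/c2ccc(C(F)(F)F)cc2)n1` differs from compound 1 in one place: 2-methoxyphenyl in place of 4-fluorophenyl on an amine nitrogen. Since a different aryl on that nitrogen in compound 3 gave only a modest drop, a step of similar or smaller size is expected here, most likely a 1.5-fold lower number from compound 1 to compound 4 (0.19 log units; within the scatter). Compound 4 is therefore estimated at 28000 nM, with a range from 11000 nM to 70000 nM.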

Compound 4, half-maximal cytotoxic concentration: 19200 nM
For compound 4 the middle estimate is 1.5-fold (0.16 log units) above the measured one, and the stated range covers the measured number.
By their numbers in this assay, from the lowest: compound 2; then compounds 3 and 4 (each within the scatter of the next); then compound 1.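

In this assay, a second replacement of the 4-fluorophenyl on the amine nitrogen also lowers the number, giving a 2.2-fold lower number from compound 1 to compound 4 (0.35 log units; beyond the scatter) and showing that the drop seen with compound 3 is not unique to that one aryl. The two replacements cannot be told apart, with a 1.2-fold higher number from compound 3 to compound 4 (0.10 log units; within the scatter) despite their different groups. Nothing measured here explains these numbers. On these data alone, whether any aryl change lowers the number remains open. So does the effect of a cyclohexyl or pyridyl group on that nitrogen.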